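The source may hold more compounds than are shown below. What is called first, only, known or untested is meant among the compounds shown, and "the series" means these compounds.

Within the data shown here, compound 2 `Cc1ccc2nc(/N=C3\C(=O)N(CN4CCCCC4)c4ccccc43)sc2c1` is one of three compounds measured in a functional assay on MDA-MB-468 cells (Homo sapiens) for cytotoxicity, read by sulforhodamine B assay, with a stated time of 48 h (a higher number here means a weaker inhibitor of growth, a lower number a stronger inhibitor of growth), where compound 2 gives 65600 nM. Compound 1 `CCN(CC)CN1C(=O)/C(=N\c2nc3ccc(C)cc3s2)c2c(Br)cccc21` gives 43100 nM and compound 3 `Cc1ccc2nc(/N=C3\C(=O)N(CN(C)C)c4ccccc43)sc2c1` gives 35500 nM; compound 2 holds the highest of the three numbers, but its gaps to both lie within the scatter. Among the measured compounds shown here, the one step measured in full is a 1.8-fold lower number from compound 2 to compound 3 (0.27 log units; within the scatter), a change of the amine and not of the aromatic ring. Compound 4 `Cc1ccc2nc(/N=C3\C(=O)N(CN4CCCCC4)c4cccc(Br)c43)sc2c1` differs from compound 2 by bromo in place of hydrogen on an aromatic carbon. For the measured compounds named here, no measured step isolates this bromo change; compounds 1 and 3, which differ in both bromo and amine, give numbers close to each other. The step from compound 2 to compound 4 in this assay is therefore expected to be a 1.1-fold lower number from compound 2 to compound 4 (0.04 log units; within the scatter), nothing beyond the scatter, and compound 4 is estimated at 60000 nM, between 25000 nM and 150000 nM.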

Compound 4, concentration for 50% growth inhibition: 24000 nM
Estimate against measurement, compound 4: 2.5-fold (0.40 log units) above, outside the stated range (below it).
By their numbers in this assay, from the lowest: compounds 4, 3, 1 and 2 (each within the scatter of the next, the first and the last beyond it).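

In this assay, among these compounds, bromo in place of hydrogen on this aromatic carbon, ortho to a fused ring, gives a 2.7-fold lower number from compound 2 to compound 4 (0.44 log units; beyond the scatter) and is the only step here beyond the scatter, though a modest one. With the bromo group present, piperidin-1-yl in place of diethylamino gives a 1.8-fold lower number from compound 1 to compound 4 (0.25 log units; within the scatter), so this amine change stays within the scatter, as did the amine change without bromo. Nothing measured here explains the bromo step.

Going by these compounds, whether chloro, fluoro or methoxy on this carbon would give a similar step remains open. So does the effect of bromo on the other carbons of this ring.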